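The source may hold more compounds than are shown below. What is called first, only, known or untested is meant among the compounds shown, and "the series" means these compounds.

Measured in a functional assay on MDA-MB-231 cells (Homo sapiens) for inhibition, read by MTT assay, with a stated time of 48 h; on this read-out higher numbers stand for weaker inhibition and lower numbers for stronger inhibition:
- compound 1 `COc1ccc(/C=C/C(=O)NO)cc1OCC(=O)Nc1ccc(Cl)c(Cl)c1`: 1900 nM
- compound 2 `COc1ccc(/C=C/C(=O)NO)cc1OCC(=O)Nc1ccccc1F`: 15600 nM
- compound 3 `COc1ccc(/C=C/C(=O)Nc2ccccc2N)cc1OCC(=O)Nc1ccccc1F`: 15500 nM

Among these three, compound 1 gives the lowest number, 1900 nM, and so shows the strongest inhibition. Compound 4 `COc1ccc(/C=C/C(=O)NO)cc1OCC(=O)Nc1cccc(F)c1` has not yet been measured. It differs from compound 1 by one change, (3-fluorophenyl in place of 3,4-dichlorophenyl on an amide-type nitrogen), which places 3-fluorophenyl in place of 3,4-dichlorophenyl on an amide-type nitrogen.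

The closest evidence is an 8.2-fold higher number from compound 1 to compound 2 (0.91 log units; beyond the scatter), where 2-fluorophenyl replaces the same 3,4-dichlorophenyl at the same place. The other measured change, a 1.0-fold lower number from compound 2 to compound 3 (0.00 log units; within the scatter), puts 2-aminophenyl in place of hydroxy. Compound 4 keeps the hydroxy, so this step says little about it. Within the data shown here, no measured compound carries 3-fluorophenyl, which leaves the first step as only a rough guide, and the true size could differ in either direction.

A move towards a higher number is therefore expected in this assay, probably somewhat smaller than the step to compound 2. The expected change is a 4.2-fold higher number from compound 1 to compound 4 (0.62 log units; beyond the scatter). Compound 4 is estimated at 8000 nM, with an expected range of 2500 nM to 20000 nM.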

Compound 4, half-maximal inhibitory concentration: 3410 nM
For compound 4 the middle estimate is 2.3-fold (0.37 log units) above the measured one; measured number inside the range.
By their numbers in this assay, from the lowest: compounds 1 and 4 (each within the scatter of the next); then compounds 3 and 2 (each within the scatter of the next).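

In this assay, replacing 3,4-dichlorophenyl with 3-fluorophenyl gives a 1.8-fold higher number from compound 1 to compound 4 (0.25 log units; within the scatter), so this swap does not separate the two compounds, although the swap to 2-fluorophenyl had moved the number beyond the scatter. The direct comparison of the two fluorophenyl groups, a 4.6-fold lower number from compound 2 to compound 4 (0.66 log units; beyond the scatter), shows that at this amide-type nitrogen the outcome depends on which fluorophenyl is attached, and that losing 3,4-dichlorophenyl does not by itself raise the number, with compound 2 the one case among these three hydroxy compounds that stands apart. Nothing available explains why 2-fluorophenyl and 3-fluorophenyl differ in this way.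

The compounds shown do not tell how 4-fluorophenyl, 3-chlorophenyl or an unsubstituted phenyl would compare at this nitrogen, so the separate contributions of each halogen and its place remain unresolved. They also leave open whether 2-aminophenyl in place of hydroxy would again leave the number unmoved when paired with 3-fluorophenyl or 3,4-dichlorophenyl, since that swap has been seen only alongside 2-fluorophenyl.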